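Cinnamic acid series: replacing the amide substituent by fluoro

The compounds below may be only part of what the source reports. "The series", "measured", "known", "first", "only" and "open" are said of these compounds alone.

The series shares the core of compound 1 `COc1ccc(/C=C\C(=O)O)c(OCc2cn(-c3ccccc3C(=O)N3CCC(O)C3)nn2)c1CC=C(C)C`, with variation on the aryl group attached to the triazole. Going by the values given here, in a functional assay on T47D cells (Homo sapiens) for cytotoxicity, read by MTT assay, with a stated time of 24 h (on this read-out lower numbers stand for stronger inhibition and higher numbers for weaker inhibition), compound 1 gives 13400 nM, the only number so far, so compound 1 is the sole reference point. Compound 2 `COc1ccc(-n2cc(COc3c(/C=C\C(=O)O)ccc(OC)c3CC=C(C)C)nn2)cc1` belongs to the same series, but in this assay compound 2 gives "not determined" (no result reported), so it gives no anchor for comparison.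

Compound 3 `COc1ccc(/C=C\C(=O)O)c(OCc2cn(-c3ccccc3F)nn2)c1CC=C(C)C` follows from compound 1 by a single change at the aryl group: fluoro in place of (3-hydroxypyrrolidin-1-yl)carbonyl on an aromatic carbon. Among the compounds with values here, no step between two measured compounds is available to calibrate the effect of this change, so the expectation rests on compound 1 alone.

Compound 3 is expected to stay close to compound 1, with a step of a 1.1-fold higher number from compound 1 to compound 3 (0.05 log units; within the scatter) that does not clearly exceed the scatter of this assay, because compound 1 at 13400 nM is already a weak inhibitor and nothing measured indicates the direction of the change. Compound 3 is therefore estimated at 15000 nM, with a range from 5000 nM to 45000 nM in this assay.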

Compound 3, half-maximal inhibitory concentration: 11000 nM
The estimate for compound 3 lay 1.4-fold (0.13 log units) above the measured number, within the range that was stated.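

In this assay, going by these compounds alone, the exchange of (3-hydroxypyrrolidin-1-yl)carbonyl for fluoro on this aromatic carbon gives a 1.2-fold lower number from compound 1 to compound 3 (0.09 log units; within the scatter) as the first step between two measured compounds. The read-out therefore does not separate the large group, with its five-membered non-aromatic ring and hydrogen-bond donor, from a single fluoro at this place, and the activity of compound 1 does not depend on the (3-hydroxypyrrolidin-1-yl)carbonyl group in this assay. No measurement bearing on why the two compounds read alike is available.

One pair cannot show whether this position is insensitive to substitution in general, or whether the two groups merely happen to land at the same level in a weak range. From the compounds shown here alone, an amine, a carboxylic acid or a longer alkyl chain on the same aromatic carbon, or a fluoro on another carbon of that ring, would show whether any group here moves the number beyond the scatter, while the shared core remains untested by these compounds.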